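The compounds below may be only part of what the source reports. "The series", "measured", "known", "first", "only" and "open" are said of these compounds alone.

Compound 2 `Cc1ccc(NC(=O)C(F)(F)F)cc1S(=O)(=O)N(C)/N=C/c1cnn2ccc(C#N)cc12` sits at the edge of what the assay can report. In an assay on isolated protein for inhibition of phosphatidylinositol 4,5-bisphosphate 3-kinase catalytic subunit beta isoform (Homo sapiens), read by 33P incorporation, with a stated time of 60 min (on this read-out lower numbers stand for stronger inhibition and higher numbers for weaker inhibition), compound 2 gives only the limit > 1000 nM, a limit and not a number. Compound 1 `Cc1ccc(Br)cc1S(=O)(=O)N(C)/N=C/c1cnn2ccc(C#N)cc12` carries bromo where compound 2 carries ((trifluoromethyl)carbonyl)amino, and in this assay compound 1 gives 620 nM. The step between them is an at least 1.6-fold higher number from compound 1 to compound 2 (0.20 log units; that floor lies within the scatter), and its floor rests on (the limit of > 1000 nM in this assay, at which 1 of the 2 values shown sits). Compound 3 `Cc1ccccc1S(=O)(=O)N(C)/N=C/c1cnn2ccc(C#N)cc12` is not yet measured; it differs from compound 2 as hydrogen in place of ((trifluoromethyl)carbonyl)amino on an aromatic carbon. Among the measured compounds shown here, the single measured step says only that replacing bromo with the amide costs at least a little potency, and nothing measured shows what hydrogen alone does at that place. Compound 3 is therefore expected near the two known values, with a wide spread: the step that the limit leaves unreadable from compound 2 to compound 3 is an estimate, and compound 3 is estimated at 1500 nM, between 400 nM and 6000 nM.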

Compound 3, half-maximal inhibitory concentration: > 1000 nM
Compound 3: no number, only a limit; the forecaster's own chance of this, stated with the estimate: 55%; the middle value is on the limit's open side.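

Hydrogen in place of bromo gives an at least 1.6-fold higher number from compound 1 to compound 3 (0.20 log units; that floor lies within the scatter), so in this assay the bare ring carbon, like the amide of compound 2, yields only a limit and not a number. Among the three groups shown on this aromatic carbon, para to a methyl group, only bromo comes with a measured value, as compound 1 gives 620 nM. The step from compound 2 to compound 3 cannot be read, because both compounds stop at the same limit: the limit of > 1000 nM in this assay, at which 2 of the 3 values shown sit.

Still open, going by these compounds, is how far past that limit compound 2 and compound 3 lie, and so whether bromo truly gives an advantage over hydrogen at this place. Also open, on these data alone, is what a chlorine atom, a methoxy group or a plain amine on this same carbon would give.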